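Chloro for difluoromethoxy: clearance notes on the series

This account rests on a few compounds, and the source may have more. Where it says the series, first, only, none or still open, it means among the compounds named here.

Measured in an in vitro ADME assay on microsomes from liver (Homo sapiens) for metabolic stability; a lower number here means slower removal, a higher number faster removal of the compound:
- compound 1 `COCc1ccccc1C1CCc2nc[nH]c2C1` gives < 7 mL.min-1.g-1; < 7 mL.min-1.g-1 (2 entries) (both entries are limits of the assay)
- compound 2 `c1ccc(C2Cc3nccn3C2)cc1` gives 15 mL.min-1.g-1; < 7 mL.min-1.g-1 (2 entries)
- compound 3 `FC(F)Oc1ccccc1C1Cc2nccn2C1` gives 22 mL.min-1.g-1

Compound 3 stands alone in this set with a single number, 22 mL.min-1.g-1, while the other two compounds give no single number to set against it. Compound 4 `Clc1ccccc1C1Cc2nccn2C1` has chloro in place of difluoromethoxy on an aromatic carbon. Going by the values given here, no measured pair shows this change, so no size of step can be read from the data. Only a small step is expected, not beyond the scatter and with no firm direction. The expected change is a 1.4-fold lower number from compound 3 to compound 4 (0.14 log units; within the scatter). For compound 4 the estimated value in this assay is 16 mL.min-1.g-1, with an expected range from 7 mL.min-1.g-1 to 35 mL.min-1.g-1. The range is kept wide because the several entries of compound 2 in this assay, 15 mL.min-1.g-1; < 7 mL.min-1.g-1 (2 entries) do not agree on one number.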

Compound 4, intrinsic clearance in microsomes: 18 mL.min-1.g-1
Beside the measured number, compound 4's estimate is 1.1-fold (0.05 log units) below it; low and high end bracket the measured number.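

In this assay, going by these compounds alone, chloro in place of difluoromethoxy on an aromatic carbon, ortho to a group of 8 heavy atoms, gives the first step that can be read: a 1.2-fold lower number from compound 3 to compound 4 (0.09 log units; within the scatter). At this position, a group of 4 heavy atoms with 1 hydrogen-bond acceptor can thus give way to a single chlorine without a change beyond the scatter, and no direction can be claimed for the exchange. Little weight belongs on so small a step, because repeat entries of one compound can part widely: the several entries of compound 2 in this assay, 15 mL.min-1.g-1; < 7 mL.min-1.g-1 (2 entries)

Open, going by these compounds, is whether an amine or a carboxylic acid at this position would move the number beyond the scatter. Equally open, on these data alone, is whether the same exchange would give a step of like size on the core of compound 1, whose two entries are limits of the assay.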